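Replacing pyridin-2-yl with phenyl on a near-inactive topoisomerase inhibitor

The source may hold more compounds than are shown below. What is called first, only, known or untested is meant among the compounds shown, and "the series" means these compounds.

Measured compounds:
compound 1 `Oc1ccc(-c2cc(-c3cccc(Cl)c3)nc(-c3ccccn3)c2)cc1` 59.4%
compound 2 `Oc1cccc(-c2cc(-c3cccc(Cl)c3)nc(-c3ccccn3)c2)c1` 0.4%
compound 3 `Oc1cccc(-c2cc(-c3ccccn3)nc(-c3ccccc3Cl)c2)c1` 0%

In an assay on isolated protein for inhibition of DNA topoisomerase 1 (Homo sapiens), with a stated time of 30 min, tested at 100 uM (on this read-out lower numbers stand for a weaker effect and higher numbers for a stronger effect at the one concentration tested), compound 2 gives 0.4%, the second highest of the three numbers. Its step to compound 3, a number 0.4 percentage points lower from compound 2 to compound 3 (within the scatter), lies within the scatter, while a number 59 percentage points lower from compound 1 to compound 2 (beyond the scatter) is beyond it. Compound 4 `Oc1cccc(-c2cc(-c3ccccc3)nc(-c3cccc(Cl)c3)c2)c1` differs from compound 2 in one place: phenyl in place of pyridin-2-yl on an aromatic carbon. Neither measured step concerns this change: a number 59 percentage points lower from compound 1 to compound 2 (beyond the scatter) followed a move of the hydroxyl group, and a number 0.4 percentage points lower from compound 2 to compound 3 (within the scatter) a move of the chlorine atom. Going by the values given here, there is thus no direct precedent, and compound 2 already sits near the floor of this assay. For compound 4 the expected step is a number 4.6 percentage points higher from compound 2 to compound 4 (within the scatter), none beyond the scatter. The estimate for compound 4 in this assay is 5%, ranging from 0% to 25%.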

Compound 4, a percentage reported as inhibition, at one concentration (the size of the read-out at that concentration, not a potency): 11.5%
For compound 4 the middle estimate is 6.5 percentage points below the measured one; the measured number falls inside the stated range.
By their numbers in this assay, from the lowest: compounds 3 and 2 (each within the scatter of the next); then compound 4; then compound 1.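

In this assay, this position responds to change: a number 11.1 percentage points higher from compound 2 to compound 4 (beyond the scatter), whereas the chlorine move from compound 2 to compound 3 left the number within the scatter. Activity at this position therefore does not depend on the ring nitrogen or hydrogen-bond acceptor of pyridin-2-yl, since phenyl lacks both, and the change brings a modest gain. Nothing available explains this gain. On these data alone, it remains open whether phenyl would have the same effect alongside the 4-hydroxyphenyl group of compound 1. As far as these compounds go, it is also open how a carboxylic acid or an aminomethyl group would fare at this position.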